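Chloro substitution on the phenyl of compound 1

A few compounds are considered here, and "the series" means these few. Any claim that something is new, unique, unknown or untested is made for them only; others in the source may bear on it.

Measured compounds:
Compound 1 `COc1cc(/C=C/C(=O)c2cccc(-n3cc(-c4ccccc4)[nH]c3=O)c2)ccc1O`: 2270 nM
Compound 2 `COc1ccc(-c2cn(-c3cccc(C(=O)/C=C/c4cc(OC)c(OC)c(OC)c4)c3)c(=O)[nH]2)cc1`: 14900 nM
Compound 3 `COc1cc(/C=C/C(=O)c2cccc(-n3cc(-c4cc(OC)c(OC)c(OC)c4)[nH]c3=O)c2)cc(OC)c1OC`: "not determined" (no result reported)

Three compounds from this series were taken into a functional assay on HOP-92 cells (Homo sapiens) for inhibition (on this read-out higher numbers stand for weaker inhibition of growth and lower numbers for stronger inhibition of growth), and two of them returned a number. Compound 1 gives 2270 nM, and compound 2 gives 14900 nM. Compound 1 thus holds the lower of the two numbers, and the gap to compound 2 lies beyond the usual scatter of repeated runs. For compound 3 the entry reads "not determined" (no result reported), so it adds nothing to the comparison.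

The compound that follows is compound 4 `COc1cc(/C=C/C(=O)c2cccc(-n3cc(-c4ccc(Cl)cc4)[nH]c3=O)c2)ccc1O`. It differs from compound 1 in a single place: chloro in place of hydrogen on an aromatic carbon. Nothing else in the two structures is different.

Among the measured compounds shown here, no step between two measured compounds of this set speaks to such a change, so the expectation rests on compound 1 alone. The step of a 1.0-fold lower number from compound 1 to compound 4 (0.01 log units; within the scatter) is expected to be small, none beyond the scatter in either direction. Compound 4 is therefore estimated to give 2200 nM in this assay , with a range from 800 nM to 6500 nM.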

Compound 4, concentration for 50% growth inhibition: 1260 nM
Beside the measured number, compound 4's estimate is 1.7-fold (0.24 log units) above it; the measured number falls inside the stated range.
By their numbers in this assay, from the lowest: compounds 4 and 1 (each within the scatter of the next); then compound 2.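

In this assay, among the compounds shown here, replacing phenyl with 4-chlorophenyl gives a 1.8-fold lower number from compound 1 to compound 4 (0.26 log units; within the scatter), the first reading in this set of a change made in one place alone, as compound 1 and compound 2 differ in more than one place. At this aromatic carbon, para to a large group, the chloro group can therefore enter without moving the number beyond the usual scatter, and compound 4 stays level with compound 1 on this read-out. For the compounds shown here, no measurement at hand bears on why the step is this small, and the single step gives no trend for this position.

What the compounds shown leave open is whether this position would remain as undemanding with a different kind of group, such as an amine, a carboxylic acid or a longer alkyl chain, in place of the chloro group. From the compounds shown here alone, it also remains open whether chloro on another carbon of the same phenyl would give a step of similar size, or whether this step would hold on a compound with the trimethoxyphenyl group of compound 2.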